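Turning One Stereocentre in a Growth Inhibitor

The source may hold more compounds than are shown below. What is called first, only, known or untested is meant among the compounds shown, and "the series" means these compounds.

- compound 1 `C=C[C@@](C)(/C=C/c1ccc(OC)cc1)CCC=C(C)C`: 45%
- compound 2 `COc1ccc(/C=C/[C@@](C)(/C=C/c2ccc(O)cc2)CCC=C(C)C)cc1`: 52%

In a functional assay on THP-1 cells (Homo sapiens) for inhibition, with a stated time of 48 h, tested at 50 uM (a higher number here means more inhibition of growth at the concentration tested, a lower number less inhibition of growth), compound 2 gives 52%. Among the measured compounds shown here, this is the higher of only two numbers, but the gap to compound 1 lies within the usual scatter, so the two cannot be told apart.

The next compound is compound 3 `COc1ccc(/C=C/[C@](C)(/C=C/c2ccc(O)cc2)CCC=C(C)C)cc1`. Its change is subtle: the two compounds have the same atoms and bonds and differ only in configuration as drawn: 1 of 3 stereo elements differ; a stereocentre at a saturated chain carbon is drawn R in compound 2 and S in compound 3. A stereocentre at a saturated chain carbon is drawn R in compound 2 and S in compound 3, so the atoms and bonds stay the same and only the configuration as drawn differs.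

For the measured compounds named here, no measured pair here shows what such a change does in this assay. With no evidence for either direction, no shift beyond the scatter is expected. The estimated step of a number 2 percentage points lower from compound 2 to compound 3 (within the scatter) is therefore small. For compound 3, the expected value is 50%, with an estimated range from 36% to 64%.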

Compound 3, percent growth inhibition at one concentration: 86%
Compound 3: the middle estimate sits 36 percentage points below what was measured; measured number outside the range, above it.
By their numbers in this assay, from the lowest: compounds 1 and 2 (each within the scatter of the next); then compound 3.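

In this assay, the configuration at this saturated chain carbon matters a great deal: drawing it S rather than R gives a number 34 percentage points higher from compound 2 to compound 3 (beyond the scatter). The change can be pinned on that one stereocentre because nothing else separates the pair: the fact that compounds 2 and 3 differ only in the configuration as drawn. Placing 2-(4-hydroxyphenyl)ethenyl instead of vinyl on the same carbon comes with a number 41 percentage points higher from compound 1 to compound 3 (beyond the scatter), but compound 2 carries that group too, so the group alone does not bring the high number.

Still open, from the compounds shown here alone, is whether the S form keeps its advantage when the hydroxyl of the 4-hydroxyphenyl group gives way to another group, such as an amine or a carboxylic acid. The compounds shown also leave open how the S form inhibits growth in these cells.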